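The source may report more compounds than this note shows. Statements on the series, on what has been measured and on what is new or still open speak of the compounds shown alone.

The shared core appears in compound 1 (`CCCCCCC[C@@H]1CC(O)=C(C(=O)CCC)C(=O)O1`), compound 2 (`CCCCCCCC[C@@H]1CC(O)=C(C(=O)CCC)C(=O)O1`), compound 3 (`CCCCCCCCC[C@@H]1CC(O)=C(C(C)=O)C(=O)O1`) and the still unmeasured compound 4 (`CCCCCCCCC[C@@H]1CC(O)=C(C(=O)CCCCC)C(=O)O1`). In an ADME assay on HepG2 cells (Homo sapiens) for cytotoxicity, read by XTT assay, with a stated time of 48 h (on this read-out lower numbers stand for higher toxicity in this test and higher numbers for lower toxicity in this test), compound 1 has the entry "not determined" (no result reported) and compound 2 gives 30 ug/mL, while compound 3 gives 71 ug/mL as the higher of the two numbers, a gap beyond the scatter. The change to compound 4 is butyl in place of hydrogen on a saturated chain carbon bound to a carbonyl carbon on a saturated chain carbon bound to a carbonyl carbon, so acetyl becomes pentylcarbonyl. Within the data shown here, no measured pair isolates this change. Among the measured compounds shown here, the only guide is compound 2 at 30 ug/mL which differs from compound 3 in more than one place and stands lower. A move to lower numbers in this assay beyond the scatter is therefore expected (a 2.8-fold lower number from compound 3 to compound 4 (0.45 log units; beyond the scatter)). For compound 4 the estimated value is 25 ug/mL (expected range 10 ug/mL to 60 ug/mL).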

Compound 4, half-maximal cytotoxic concentration: 15 ug/mL
Compound 4: middle estimate off by 1.7-fold (0.22 log units), on the high side; the measured number falls inside the stated range.
By their numbers in this assay, from the lowest: compounds 4 and 2 (each within the scatter of the next); then compound 3.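

Among these compounds, compound 4 gives the only reading here of this change alone: in this assay, butyl in place of hydrogen on a saturated chain carbon bound to a carbonyl carbon brings a 4.7-fold lower number from compound 3 to compound 4 (0.68 log units; beyond the scatter) and so shifts the result toward higher toxicity in this test. Acetyl to pentylcarbonyl is thus enough by itself to move the number beyond the scatter. Nothing available accounts for this step.

From the compounds shown here alone, with only these two chain lengths compared on one core, the effect of a longer chain here remains open. So does that of an amine or a carboxylic acid at the end of this chain.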